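A few compounds are considered here, and "the series" means these few. Any claim that something is new, unique, unknown or untested is made for them only; others in the source may bear on it.

Measured in a functional assay on HeLa cells (Homo sapiens) for inhibition, read by CCK-8 assay, with a stated time of 48 h; on this read-out higher numbers stand for weaker inhibition and lower numbers for stronger inhibition:
- Compound 1 `COc1cc(-c2ccnc3cc(-c4ccc(Cl)cc4)nn23)cc(OC)c1OC`: 1490 nM
- Compound 2 `COc1cc(-c2ccnc3cc(-c4ccc(N(C)C)cc4)nn23)cc(OC)c1OC`: 378 nM
- Compound 3 `COc1ccc(-c2cc3nccc(-c4cc(OC)c(OC)c(OC)c4)n3n2)cc1`: 373 nM

Compound 3 sits at the low end of these numbers together with compound 2, the gap being a 1.0-fold lower number from compound 2 to compound 3 (0.01 log units; within the scatter). Compound 1 stands apart, with a 4.0-fold lower number from compound 1 to compound 3 (0.60 log units; beyond the scatter) and a 3.9-fold lower number from compound 1 to compound 2 (0.60 log units; beyond the scatter).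

Compound 4 `COc1ccc(-c2cc3nccc(-c4cc(OC)c(OC)c(OC)c4)n3n2)cc1N` keeps all of compound 3 and adds one group: amino in place of hydrogen on an aromatic carbon. This amino in place of hydrogen lies ortho to a methoxy group and turns 4-methoxyphenyl into 3-amino-4-methoxyphenyl.

Among the compounds with values here, no measured step adds a group at this place, so the guidance is indirect. The closest evidence is the three steps above, all made on the same six-membered aromatic ring. Two were modest and one stayed within the scatter. A modest step towards a lower number is therefore expected in this assay, though a step within the scatter remains possible. The estimated change is a 3.1-fold lower number from compound 3 to compound 4 (0.49 log units; beyond the scatter). For compound 4 the expected value is 120 nM, with an estimated range from 20 nM to 450 nM.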

Compound 4, half-maximal inhibitory concentration: 283 nM
Compound 4: middle estimate off by 2.4-fold (0.37 log units), on the low side; the range from low to high includes it.
By their numbers in this assay, from the lowest: compounds 4, 3 and 2 (each within the scatter of the next); then compound 1.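

In this assay, the added amino group, ortho to a methoxy group, gives a 1.3-fold lower number from compound 3 to compound 4 (0.12 log units; within the scatter), so this place on the 4-methoxyphenyl group accepts amino without a step beyond the scatter. Replacing 4-(dimethylamino)phenyl with 3-amino-4-methoxyphenyl gives a 1.3-fold lower number from compound 2 to compound 4 (0.13 log units; within the scatter), while replacing 4-chlorophenyl with the same group gives a 5.3-fold lower number from compound 1 to compound 4 (0.72 log units; beyond the scatter), which leaves compound 4 in one group with compound 2 and compound 3 and compound 1 apart from them. Nothing measured here explains these results.

On these data alone, whether a hydroxyl, a methylamino or an acetamide group at this place would read like amino stays open. So does whether amino would give the same result on a phenyl group that lacks the methoxy group.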